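This account rests on a few compounds, and the source may have more. Where it says the series, first, only, none or still open, it means among the compounds named here.

Measured so far:
- compound 1, `O=C(O)c1ccccc1-c1ccc(CCc2ncc(Cc3ccccc3F)[nH]2)cc1`: 9.5 nM
- compound 2, `O=C(O)c1ccccc1-c1ccc(CCc2ncc(-c3ccccc3)[nH]2)cc1`: 872 nM
- compound 3, `Cc1cccc(Cc2cnc(CCc3ccc(-c4ccccc4C(=O)O)cc3)[nH]2)c1`: 75 nM

These three compounds were tested in an in vitro functional assay on cells for agonist activity at Bombesin receptor subtype-3 (Mus musculus), read by luminescence and calcium flux; on this read-out higher numbers stand for an effect only at larger amounts of compound and lower numbers for an effect already at smaller amounts. Compound 3 stands second of the three: next to compound 1, which gives 9.5 nM, with a 7.9-fold higher number from compound 1 to compound 3 (0.90 log units; beyond the scatter); furthest from compound 2, which gives 872 nM, with a 12-fold lower number from compound 2 to compound 3 (1.07 log units; beyond the scatter). Compound 4, `CC(C)(C)CCc1cnc(CCc2ccc(-c3ccccc3C(=O)O)cc2)[nH]1`, is not yet measured. It differs from compound 3 in one place: neopentyl in place of 3-methylphenyl on a saturated chain carbon bound to an aromatic carbon. For the measured compounds named here, two measured steps bear on this. From compound 1 to compound 3 the number rose: a 7.9-fold higher number from compound 1 to compound 3 (0.90 log units; beyond the scatter), a modest change when one group on the saturated chain carbon is swapped for another. From compound 2 to compound 3 it fell: a 12-fold lower number from compound 2 to compound 3 (1.07 log units; beyond the scatter), a large change when the group on the aromatic carbon is altered. Both show this position responds strongly to changes, and the ring disappears here entirely, so a higher number in this assay is expected for compound 4, with a 4.0-fold higher number from compound 3 to compound 4 (0.60 log units; beyond the scatter). Compound 4 is therefore estimated at 300 nM, in the range 60 nM to 1500 nM.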

Compound 4, half-maximal effective concentration: 6.2 nM
Estimate against measurement, compound 4: 48-fold (1.68 log units) above; the whole stated range lies above it.
By their numbers in this assay, from the lowest: compounds 4 and 1 (each within the scatter of the next); then compound 3; then compound 2.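

In this assay, a ring is not needed on the saturated chain carbon bound to an aromatic carbon: neopentyl, with no ring, replaces 3-methylphenyl and the number drops (a 12-fold lower number from compound 3 to compound 4 (1.08 log units; beyond the scatter)). Against 2-fluorophenyl, neopentyl gives no change that can be told from the scatter (a 1.5-fold lower number from compound 1 to compound 4 (0.19 log units; within the scatter)), so a ring-free group and a fluorinated ring both fit here. The gain over phenyl on the aromatic carbon also proves the largest seen so far (a 140-fold lower number from compound 2 to compound 4 (2.15 log units; beyond the scatter)), yet nothing measured here explains any of these results.

As far as these compounds go, it remains open whether the branched end of the 3,3-dimethylbutyl group matters, which a straight hexyl chain would test. A chain ending in an amine or a hydroxyl group could also show how much this position accepts.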